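Swapping the amide substituent on a quinolinyl oxadiazole piperidine

A few compounds are considered here, and "the series" means these few. Any claim that something is new, unique, unknown or untested is made for them only; others in the source may bear on it.

Of the compounds shown here, three sharing a common core have been measured in a functional assay on Shh Light II cells (Mus musculus) for inhibition, read by a luciferase reporter; a higher number here means a weaker inhibitor, a lower number a stronger inhibitor. Compound 1 `O=C(NC1CCCCC1)N1CCN(c2nc(-c3ccc4ccccc4n3)no2)CC1` gives 53 nM, compound 2 `O=C(CC1CCCCCC1)N1CCC(c2nc(-c3ccc4ccccc4n3)no2)CC1` gives 840 nM, and compound 3 `O=C(NC1CCS(=O)(=O)CC1)N1CCC(c2nc(-c3ccc4ccccc4n3)no2)CC1` gives 360 nM. Compound 3 therefore holds the second highest number of the three: compound 2 sits nearest to it, while compound 1 lies furthest away with a clearly lower number. Compound 1 differs from compound 3 in more than one place, so its value can only be read as a comparison, not as a single step. Among the measured compounds shown here, the one single-point step available is a 2.3-fold lower number from compound 2 to compound 3 (0.37 log units; beyond the scatter), a modest change at the carbonyl carbon.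

Compound 4 `COc1ccccc1N(C)C(=O)N1CCC(c2nc(-c3ccc4ccccc4n3)no2)CC1` has not yet been measured. It changes compound 3 at that same carbonyl carbon: (2-methoxyphenyl)(methyl)amino in place of (1,1-dioxothian-4-yl)amino on a carbonyl carbon. For the measured compounds named here, the only comparable step, from compound 2 to compound 3, shows that exchanging the group on this carbonyl carbon shifts this assay only modestly, so a step of similar size, or none beyond the scatter, is expected here, with no firm direction indicated. The expected result for compound 4 is 450 nM, within a range from 150 nM to 1300 nM, which would correspond to an estimated 1.3-fold higher number from compound 3 to compound 4 (0.10 log units; within the scatter).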

Compound 4, half-maximal inhibitory concentration: 3100 nM
Compound 4: middle estimate off by 6.9-fold (0.84 log units), on the low side, and the stated range ends below it.
By their numbers in this assay, from the lowest: compound 1; then compound 3; then compound 2; then compound 4.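

The group on this carbonyl carbon can matter more than the first comparison suggested: in this assay, the earlier exchange gave a 2.3-fold lower number from compound 2 to compound 3 (0.37 log units; beyond the scatter), whereas the new one gives an 8.6-fold higher number from compound 3 to compound 4 (0.94 log units; beyond the scatter), a clearly wider step in the opposite direction. The new group also does worse than the cycloheptylmethyl group, with a 3.7-fold higher number from compound 2 to compound 4 (0.57 log units; beyond the scatter), so among these three compounds, which differ only at this carbonyl carbon, the lowest number belongs to compound 3 and the highest to compound 4. The exchange from compound 3 to compound 4 removes a hydrogen-bond donor and replaces a non-aromatic ring with an aromatic one, but nothing available explains the weaker inhibition or separates these differences.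

Among the compounds shown here, the single step from compound 3 to compound 4 changes several features together, so the contribution of each remains unknown. (2-Methoxyphenyl)amino, which keeps the same ring but has the amide hydrogen in place of the methyl on nitrogen, could show whether that methyl or the ring accounts for more of the change, and the unsubstituted phenylamino group could do the same for the methoxy group.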